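Removing the Chloro Group in a Weakly Active Series

The source may hold more compounds than are shown below. What is called first, only, known or untested is meant among the compounds shown, and "the series" means these compounds.

Of the compounds shown here, three have been measured in a functional assay on MGC-803 cells (Homo sapiens) for inhibition; on this read-out higher numbers stand for weaker inhibition and lower numbers for stronger inhibition. Compound 2 `CCN(CC)CCNC(=O)CC(CC(=O)N(C)C1Cc2ccccc2C1)c1ccc(Cl)cc1` gives 81200 nM. Compound 3 `CCNCCNC(=O)CC(CC(=O)N(CC)C1Cc2ccccc2C1)c1ccc(Cl)cc1` gives 43800 nM; the difference between the cores of compound 2 and compound 3 is not broken down here. For compound 1 `CCN(CC)CCNC(=O)CC(CC(=O)N(C)C1Cc2ccccc2C1)c1ccccc1` the result is a limit of the assay, > 100000 nM, recorded as the limit of > 100000 nM in this assay, at which 1 of the 3 values shown sits. Within this set the change hydrogen in place of chloro on an aromatic carbon has been measured once, giving an at least 1.2-fold higher number from compound 2 to compound 1 (0.09 log units; that floor lies within the scatter). Compound 4 `CCNCCNC(=O)CC(CC(=O)N(CC)C1Cc2ccccc2C1)c1ccccc1` carries the same change relative to compound 3, described as hydrogen in place of chloro on an aromatic carbon, at the same place on the ring. For compound 4 the expected step is a 2.1-fold higher number from compound 3 to compound 4 (0.31 log units; beyond the scatter), resting on the measured step of an at least 1.2-fold higher number from compound 2 to compound 1 (0.09 log units; that floor lies within the scatter). Compound 4 is estimated at 90000 nM, with a likely range from 40000 nM to 200000 nM.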

Compound 4, half-maximal inhibitory concentration: > 100000 nM
Compound 4: no number, only a limit; the forecaster's own chance of this, stated with the estimate: 50%; middle value at least 1.1-fold (0.04 log units) away from the limit.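

On the core of compound 3, replacing the 4-chlorophenyl with phenyl gives an at least 2.2-fold higher number from compound 3 to compound 4 (0.35 log units; beyond the scatter). In this assay compound 4 gives > 100000 nM, which is a limit of the assay and not a number. The change thus leaves the phenyl compound at this limit on both cores, but how large the step really is on either core, and whether the two sizes match, cannot be told: the same change on two cores in this assay, an at least 1.2-fold higher number (0.09 log units; that floor lies within the scatter) from compound 2 to compound 1 and an at least 2.2-fold higher number (0.35 log units; beyond the scatter) from compound 3 to compound 4; the limit leaves it open whether they differ

Much of this small set lies beyond what the read-out can resolve: the limit of > 100000 nM in this assay, at which 2 of the 4 values shown sit. On these data alone, it remains open how other groups on the same aromatic carbon, such as fluoro, methoxy or a nitrile, would behave on these cores.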